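The source may hold more compounds than are shown below. What is called first, only, known or untested is meant among the compounds shown, and "the series" means these compounds.

Compound 1 `S=C(NNc1nncc2ccccc12)Nc1ccccc1`: 56 nM
Compound 2 `COc1ccc(NC(=S)NNc2nncc3ccccc23)cc1`: 47 nM
Compound 3 `Cc1cc(NS(=O)(=O)c2ccc(Nc3nncc4ccccc34)cc2)no1`: 33 nM

In a functional assay on UO-31 cells (Homo sapiens) for antiproliferative activity, read by sulforhodamine B assay, with a stated time of 72 h (on this read-out higher numbers stand for weaker inhibition and lower numbers for stronger inhibition), compound 1 gives 56 nM, which lies within the scatter of the values for compound 2 and compound 3. Compound 4 `NC(=S)NNc1nncc2ccccc12` has not yet been measured. It carries hydrogen in place of phenyl on an amide-type nitrogen. For the measured compounds named here, only one measured step bears on this, a 1.2-fold lower number from compound 1 to compound 2 (0.08 log units; within the scatter), and it merely places methoxy on an aromatic carbon of the phenyl that compound 4 lacks. Going by the values given here, no measured step removes the whole group, so the size of the change is poorly bounded, and a moderately higher number is expected. The estimated step is a 2.3-fold higher number from compound 1 to compound 4 (0.37 log units; beyond the scatter). Compound 4 is expected at 130 nM, with an estimated range of 35 nM to 500 nM.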

Compound 4, half-maximal inhibitory concentration: 33 nM
For compound 4 the middle estimate is 3.9-fold (0.60 log units) above the measured one, and the stated range ends above it.
By their numbers in this assay, from the lowest: compounds 3, 4, 2 and 1 (each within the scatter of the next).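

The result gives a 1.7-fold lower number from compound 1 to compound 4 (0.23 log units; within the scatter) when hydrogen replaces the whole phenyl on the amide-type nitrogen in this assay. The phenyl can therefore go from this position without a change that stands out from the scatter, which the methoxy step could not show, as it left that group in place. No evidence here bears on why this is so. The compounds shown leave open whether a methyl, a longer chain or a benzyl on this nitrogen would read the same. They also leave open whether this loss of phenyl would read the same in a second assay or cell line.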